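Swapping the Formyl Proline Ester for a Lactam

The compounds below may be only part of what the source reports. "The series", "measured", "known", "first", "only" and "open" are said of these compounds alone.

Going by the values given here, compound 2 `CCCCCCCCCCC[C@@H](C[C@@H]1OC(=O)[C@H]1CCCCCC)OC(=O)[C@@H]1CCCN1C=O` is the only compound here with a measured number in an assay on COS-7 cells for inhibition of diacylglycerol lipase-alpha (Homo sapiens), read by scintillation counting (on this read-out higher numbers stand for weaker inhibition and lower numbers for stronger inhibition), where compound 2 gives 1100 nM. Compound 1 `CCCCCCCCCCC[C@@H](C[C@@H]1OC(=O)[C@H]1CCCCCC)OC(=O)CCC(C)C` gives only a limit in this assay, > 25000 nM, and that limit is the limit of > 25000 nM in this assay, at which 1 of the 2 values shown sits. Among the compounds with values here, the one measured step, an at least 22-fold lower number from compound 1 to compound 2 (1.35 log units; beyond the scatter), is large and runs from that limit to a number, so its exact size is not known beyond being at least that big.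

Compound 3 `CCCCCCCCCCC[C@@H](C[C@@H]1OC(=O)[C@H]1CCCCCC)OC(=O)[C@@H]1CCC(=O)N1` differs from compound 2 in one place: 5-oxopyrrolidin-2-yl in place of 1-formylpyrrolidin-2-yl on a carbonyl carbon. The change keeps the five-membered ring and its nitrogen but moves the carbonyl into the ring and leaves a hydrogen on the nitrogen. The measured step shows that the group on this carbonyl carbon matters greatly, yet it compares a plain isopentyl chain with the formyl ring, not two rings with each other, so it gives direction only loosely.

For compound 3 a modest loss is expected, a 2.3-fold higher number from compound 2 to compound 3 (0.36 log units; beyond the scatter), with an estimate of 2500 nM and a range from 600 nM to 10000 nM.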

Compound 3, half-maximal inhibitory concentration: 100 nM
Estimate against measurement, compound 3: 25-fold (1.40 log units) above; measured number outside the range, below it.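

With the five-membered ring kept on this carbonyl carbon, putting 5-oxopyrrolidin-2-yl in place of 1-formylpyrrolidin-2-yl gives an 11-fold lower number from compound 2 to compound 3 (1.04 log units; beyond the scatter) in this assay, so what the ring carries matters, and not only whether a ring is present. The entering group has a hydrogen-bond donor that the leaving group lacks and also has fewer heavy atoms, and these two differences come together in this single change, so the result cannot separate them. Set against the plain isopentyl chain, the same group gives an at least 250-fold lower number from compound 1 to compound 3 (2.39 log units; beyond the scatter), and that step starts from a limit and not from a number: the limit of > 25000 nM in this assay, at which 1 of the 3 values shown sits.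

Going by these compounds, what a methyl group on the ring nitrogen of the 5-oxopyrrolidin-2-yl group would do remains open, and with it the question of whether the amide hydrogen is what separates these two numbers. Also open, on these data alone, is how a six-membered lactam, or the opposite configuration at the ring stereocentre, would read in this assay.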